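This account rests on a few compounds, and the source may have more. Where it says the series, first, only, none or still open, it means among the compounds named here.

All numbers below come from a functional assay on FM3A cells (Mus musculus) for inhibition, read by cell counting, with a stated time of 2 days; on this read-out lower numbers stand for stronger inhibition and higher numbers for weaker inhibition.

Measured so far:
compound 1 `C=C(Br)C(=O)Nc1cccc(-c2cn3nc(-c4ccc(OCC)cc4)sc3n2)c1`: 1100 nM
compound 2 `Nc1cccc(-c2cn3c(-c4ccc(Cl)cc4)csc3n2)c1`: 11000 nM
compound 3 `CCc1ccc(-c2nn3cc(-c4cccc(N)c4)nc3s2)cc1`: 8200 nM

Among the three values compound 3 stands second highest. Its nearest neighbour is compound 2, a slightly higher number that falls within the usual scatter, so no order between the two is claimed. Within the data shown here, the furthest is compound 1, whose markedly lower number lies beyond the scatter; compound 1 carries a different core and a different set of substituents, so no single step connects it to compound 3, and only the two values themselves can be compared.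

The next compound, compound 4 `Cc1ccc(-c2nn3cc(-c4cccc(N)c4)nc3s2)cc1`, differs from compound 3 in one place: hydrogen in place of methyl on a saturated chain carbon bound to an aromatic carbon. Cut one bond further out, the same difference reads ethyl to methyl. Among the measured compounds shown here, no step between measured compounds mirrors this change, so nothing shows its effect directly. A change of this size on a saturated chain is expected to move this assay little, in no particular direction, and not beyond the scatter. Compound 4 is therefore estimated at 9000 nM, with a range of 4000 nM to 20000 nM. The expected step, a 1.1-fold higher number from compound 3 to compound 4 (0.04 log units; within the scatter), is essentially none.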

Compound 4, half-maximal inhibitory concentration: 5800 nM
Compound 4: middle estimate off by 1.6-fold (0.19 log units), on the high side, and the stated range covers the measured number.
By their numbers in this assay, from the lowest: compound 1; then compounds 4, 3 and 2 (each within the scatter of the next).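

Hydrogen in place of methyl on a saturated chain carbon bound to an aromatic carbon, which reads as ethyl to methyl when cut one bond further out, gives the first single-place step in the series: in this assay, the step is a 1.4-fold lower number from compound 3 to compound 4 (0.15 log units; within the scatter); this places the two compounds within the usual scatter of each other. At this position, then, the two chain lengths are not told apart on this read-out, and the pair gives no sign that the ethyl to methyl change matters here. No measurement at hand bears on the reason for this result.

As far as these compounds go, the pair covers only ethyl and methyl at this place, so it remains open whether a longer chain such as butyl, a hydroxyl or a carboxylic acid would give a step beyond the scatter. Compound 1 (1100 nM) differs from compound 4 in more than one place, so no single change can yet be tied to its number, and the contribution of each of those differences remains unresolved.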